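A few compounds are considered here, and "the series" means these few. Any claim that something is new, unique, unknown or untested is made for them only; others in the source may bear on it.

In a functional assay on HT-29 cells (Homo sapiens) for antiproliferative activity, read by MTT assay, with a stated time of 72 h (on this read-out higher numbers stand for weaker inhibition and lower numbers for stronger inhibition), compound 1 (`C=CC(=O)Nc1nc(-c2ccccc2)cs1`) gives 6600 nM and compound 2 (`C=CC(=O)Nc1nc(-c2ccccc2Cl)cs1`) gives 10200 nM while compound 3 (`C=CC(=O)Nc1nc(-c2cccc(Cl)c2)cs1`) gives 11000 nM so compound 1 stands within the scatter of both others. Compound 4 (`C=CC(=O)Nc1nc(-c2ccc(C)cc2)cs1`) differs from compound 1 by one change (methyl in place of hydrogen on an aromatic carbon), methyl in place of hydrogen on an aromatic carbon, para to a large group. Going by the values given here, no measured step covers methyl. The closest evidence is chloro in place of hydrogen on an aromatic carbon, with steps (a 1.5-fold higher number from compound 1 to compound 2 (0.19 log units; within the scatter)) and (a 1.7-fold higher number from compound 1 to compound 3 (0.22 log units; within the scatter)) that both stay within the scatter, so no step beyond the scatter is expected in this assay here. Compound 4 is estimated at 7000 nM with an expected range from 3200 nM to 15000 nM in this read-out. The expected step (a 1.1-fold higher number from compound 1 to compound 4 (0.03 log units; within the scatter)) is accordingly small.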

Compound 4, half-maximal inhibitory concentration: 16100 nM
Compound 4: the middle estimate sits 2.3-fold (0.36 log units) below what was measured; measured number outside the range, above it.
By their numbers in this assay, from the lowest: compounds 1, 2, 3 and 4 (each within the scatter of the next, the first and the last beyond it).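

In this assay, methyl in place of hydrogen on an aromatic carbon, para to a large group, gives a 2.4-fold higher number from compound 1 to compound 4 (0.39 log units; beyond the scatter), a modest step and the first in this set to pass beyond the scatter. The chloro replacements on this ring stayed within the scatter, so the methyl result shows that one added heavy atom on it can shift this read-out measurably. Nothing available here accounts for this step. The compounds shown leave open whether chloro, methoxy or an amine at this same place would give a step like that of methyl.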